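This account rests on a few compounds, and the source may have more. Where it says the series, first, only, none or still open, it means among the compounds named here.

In a physicochemical assay for lipophilicity, measured as octanol-water partition (on this read-out lower numbers stand for lower lipophilicity and higher numbers for higher lipophilicity), compound 1 (`CC(C)[C@@H]1CC[C@@H](C)C[C@H]1OC(=O)c1cccc([N+](=O)[O-])c1`) is the lower of the two measured compounds at 4.78 and compound 2 (`Cc1ccc(C(=O)O[C@@H]2C[C@H](C)CC[C@H]2C(C)C)cc1`) stands higher at 5.29 by more than the scatter. Compound 3 (`CC(C)[C@@H]1CC[C@@H](C)C[C@H]1OC(=O)c1cccc(Cl)c1`) differs from compound 1 by chloro in place of nitro on an aromatic carbon. Going by the values given here, no measured step covers this change, so the only guides are the structural change itself and compound 2 at 5.29 in the same series. A rise in this assay beyond the scatter is expected, with a number 0.67 log units higher from compound 1 to compound 3 (beyond the scatter) as the estimated step. For compound 3 the estimated value is 5.45 with an expected range from 5.1 to 5.8 in this series.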

Compound 3, partition coefficient: 5.34
Compound 3: middle estimate off by 0.11 log units, on the high side; the measured number falls inside the stated range.
By their numbers in this assay, from the lowest: compound 1; then compounds 2 and 3 (each within the scatter of the next).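

In this assay, the change of nitro to chloro on an aromatic carbon, meta to a large group, gives a number 0.56 log units higher from compound 1 to compound 3 (beyond the scatter), a modest step on the otherwise shared core. Going by these compounds alone, this is the first single-place comparison, and it shows that this position can shift the read-out beyond the usual scatter. No supporting measurement accounts for the size or direction of this step.

Still open, on these data alone, is how an amine, a carboxylic acid or a methoxy group in this same place would read in this assay. As far as these compounds go, whether the nitro-to-chloro step carries over to another core also remains open.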